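Swapping the azole on compound 3 for an imidazole

The source may report more compounds than this note shows. Statements on the series, on what has been measured and on what is new or still open speak of the compounds shown alone.

Measured so far in a functional assay with Alpha-1B adrenergic receptor (Homo sapiens) as the target, read by calcium flux; a higher number here means a larger maximal response, a lower number a smaller maximal response:
compound 1 `Cn1cccc1-c1ccccc1NCC1=NCCN1`, 0%
compound 2 `Cn1cc(-c2ccccc2NCC2=NCCN2)cn1`, 0%
compound 3 `Cn1ccc(-c2ccccc2NCC2=NCCN2)n1`, 33%

Compound 3 stands highest of the three; its nearest neighbour is compound 1 (a number 33 percentage points higher from compound 1 to compound 3 (beyond the scatter)) and the furthest compound 2 (a number 33 percentage points higher from compound 2 to compound 3 (beyond the scatter)). Compound 4 `Cn1ccnc1-c1ccccc1NCC1=NCCN1` differs from compound 3 by 1-methyl-1H-imidazol-2-yl in place of 1-methyl-1H-pyrazol-3-yl on an aromatic carbon. Both measured steps onto compound 3 were large and in the same direction, so a change of azole at this carbon has moved the maximal response strongly before; compounds 1 and 2 show that two other azoles gave no response at all. Compound 4 is therefore expected to fall back toward compound 1 and compound 2, an estimated step of a number 23 percentage points lower from compound 3 to compound 4 (beyond the scatter), with wide uncertainty. Compound 4 is estimated at 10%, between 0% and 35%.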

Compound 4, largest response reached (reported as maximal response), in percent of the reference or control that the assay uses: 104%
Compound 4: middle estimate off by 94 percentage points, on the low side, outside the stated range (above it).
By their numbers in this assay, from the lowest: compounds 1 and 2 (each within the scatter of the next); then compound 3; then compound 4.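

In this assay, 1-methyl-1H-imidazol-2-yl on this aromatic carbon exceeds every earlier azole (a number 71 percentage points higher from compound 3 to compound 4 (beyond the scatter)), and the gap is wider still against the two silent compounds (a number 104 percentage points higher from compound 2 to compound 4 (beyond the scatter); a number 104 percentage points higher from compound 1 to compound 4 (beyond the scatter)). The group that leaves and the group that enters have the same atoms and the same counts of donors and acceptors, so those counts do not separate compound 3 from compound 4, and only the way the ring atoms are joined differs. No data shown account for the size of this step. As far as these compounds go, it remains open whether an ethyl group in place of the methyl on the imidazole would keep this response. The same holds for an amine added to that ring, or for a thiazole in its place.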